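Furan for thiophene at the saturated ring carbon

The source may hold more compounds than are shown below. What is called first, only, known or untested is meant among the compounds shown, and "the series" means these compounds.

Measured so far:
compound 1 `CC1=C(C(=O)OC(C)C)C(c2ccsc2)N/C(=N/C#N)N1` — 647 nM
compound 2 `CCOC(=O)C1=C(C)N/C(=N\C#N)NC1c1ccsc1` — 461 nM
compound 3 `CC1=C(C(=O)OC(C)C)C(c2ccco2)N/C(=N/C#N)N1` — 24.3 nM

In an assay on HEK293 cells for displacement of a labelled ligand from adenosine receptor A2b (Homo sapiens), with a stated time of 30 min (on this read-out higher numbers stand for weaker inhibition and lower numbers for stronger inhibition), compound 2 stands second highest of the three numbers; compound 1 is its nearest neighbour, and a 1.4-fold lower number from compound 1 to compound 2 (0.15 log units; within the scatter), while compound 3 gives a clearly lower number, beyond the scatter. Compound 4 `CCOC(=O)C1=C(C)N/C(=N\C#N)NC1c1ccoc1` differs from compound 2 only in the aryl group: furan-3-yl in place of thiophen-3-yl on a saturated ring carbon. The step that bears on this is a 27-fold lower number from compound 1 to compound 3 (1.43 log units; beyond the scatter), a large drop, although there the entering group was furan-2-yl rather than furan-3-yl, so the attachment point is not the same. A lowering of the number in this assay is therefore expected for compound 4, probably smaller than that of compound 3 given the uncertainty, with a 10-fold lower number from compound 2 to compound 4 (1.01 log units; beyond the scatter). Compound 4 is estimated at 45 nM, within 10 nM to 250 nM.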

Compound 4, inhibition constant: 102 nM
Compound 4: middle estimate off by 2.3-fold (0.36 log units), on the low side, within the range that was stated.
By their numbers in this assay, from the lowest: compound 3; then compound 4; then compounds 2 and 1 (each within the scatter of the next).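

In this assay, furan-3-yl in place of thiophen-3-yl on the saturated ring carbon gives a 4.5-fold lower number from compound 2 to compound 4 (0.66 log units; beyond the scatter), with the attachment point of the ring unchanged. The earlier furan step, a 27-fold lower number from compound 1 to compound 3 (1.43 log units; beyond the scatter), moved the attachment point as well, so only the new step shows oxygen for sulfur in the ring on its own. Nothing on hand accounts for this step. The compounds shown leave open whether furan-2-yl and furan-3-yl differ when all else is the same. Going by these compounds, how a phenyl or pyridin-3-yl group would fare on this carbon also stays open.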